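A few compounds are considered here, and "the series" means these few. Any claim that something is new, unique, unknown or untested is made for them only; others in the source may bear on it.

Compound 1 `CC1(C)CC(=O)c2s/c(=N/C3CCCCC3)oc2C1`: in a functional assay on NCI-H23 cells (Homo sapiens) for antiproliferative activity, read by sulforhodamine B assay (on this read-out lower numbers stand for stronger inhibition of growth and higher numbers for weaker inhibition of growth), compound 1 gives 12500 nM.
Compound 2 `CC1(C)CC(=O)c2s/c(=N/c3ccc(Cl)cc3)oc2C1`: in this assay compound 2 gives 11600 nM.
Compound 3 `CC1CC(=O)c2s/c(=N/c3ccc(Cl)cc3)oc2C1`: in this assay compound 3 gives 13500 nM.

Compound 2 carries the lowest of these three numbers, but all three lie within the usual scatter of one another, so no order among them can be read from the data. For the measured compounds named here, the single step between measured compounds that differ in one place, a 1.2-fold higher number from compound 2 to compound 3 (0.07 log units; within the scatter), also stays within the scatter; it concerns a methyl on the saturated ring, not the aromatic ring.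

Compound 4 `CC1(C)CC(=O)c2s/c(=N/c3ccc(F)cc3)oc2C1` differs from compound 2 by fluoro in place of chloro on an aromatic carbon. Going by the values given here, no measured pair changes this halogen, so nothing among the measured compounds speaks directly to this swap, and the one measured step elsewhere in the molecule is small. The expectation is therefore a step of a 1.0-fold higher number from compound 2 to compound 4 (0.01 log units; within the scatter) in this assay, meaning none beyond the scatter. Compound 4 is estimated at 12000 nM, with a range from 5000 nM to 30000 nM.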

Compound 4, concentration for 50% growth inhibition: 3360 nM
Beside the measured number, compound 4's estimate is 3.6-fold (0.55 log units) above it; the measured number lies below the stated range.
By their numbers in this assay, from the lowest: compound 4; then compounds 2, 1 and 3 (each within the scatter of the next).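

In this assay, for the compounds shown here, the halogen on the aromatic ring proves to matter: the swap gives a 3.5-fold lower number from compound 2 to compound 4 (0.54 log units; beyond the scatter) and is the only step in this small set that lies beyond the scatter. The earlier compounds shown here, whose numbers all sat within the scatter of one another, gave no sign that a single change could move this read-out, whereas this aromatic carbon, para to a large group, responds to the exchange of just one heavy atom for another. Nothing at hand explains why fluoro gives the lower number here.

From the compounds shown here alone, with only chloro and fluoro at this carbon, it remains open how hydrogen, a methoxy group, an amine or a nitrile would compare there. Going by these compounds, it is also open whether the same swap would give a similar step on the core of compound 3, which lacks one of the two methyl groups.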